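A few compounds are considered here, and "the series" means these few. Any claim that something is new, unique, unknown or untested is made for them only; others in the source may bear on it.

Values in a functional assay on HUVEC cells (Homo sapiens) for inhibition, with stated times of 2 h and 72 h (on this read-out lower numbers stand for stronger inhibition and higher numbers for weaker inhibition), are as follows, and each one is a limit, not a number:

compound 1 `COc1cc2nccc(Oc3ccc4c(NC(=O)c5cccc(C(F)(F)F)c5)nn(C)c4c3)c2cc1OC` gives > 1000 nM as a limit
compound 2 `COc1cc2nccc(Oc3ccc4c(NC(=O)c5cc(C(F)(F)F)cc(C(F)(F)F)c5)nn(C)c4c3)c2cc1OC` gives > 1000 nM as a limit
compound 3 `COc1ccc(C(=O)Nc2nn(C)c3cc(Oc4ccnc5cc(OC)c(OC)cc45)ccc23)cc1` gives > 1000 nM as a limit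

Compound 3 therefore has no exact position on the scale, and it shares its reading with the other two compounds. Compound 4 `COc1cc2nccc(Oc3ccc4c(NC(=O)c5ccc(C(F)(F)F)cc5)nn(C)c4c3)c2cc1OC` differs from it by a single change trifluoromethyl in place of methoxy on an aromatic carbon that puts trifluoromethyl in place of methoxy on an aromatic carbon, para to a large group.

Going by the values given here, two measured steps bear on this change. Exchanging 3-(trifluoromethyl)phenyl for 4-methoxyphenyl is a step that the two limits leave unreadable from compound 1 to compound 3 and adding a second trifluoromethyl is a step that the two limits leave unreadable from compound 1 to compound 2 so neither gives a size to carry over. Among the compounds with values here, what remains is the limit of > 1000 nM in this assay, at which 3 of the 3 values shown sit, as the only guide. Compound 4 is thus expected to remain weak in this assay and probably to report a limit as well. The expected change is a step that the limit leaves unreadable from compound 3 to compound 4 and no clear direction can be foreseen. For compound 4 the estimated value is 2000 nM with an expected range of 800 nM to 6000 nM around it.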

Compound 4, half-maximal inhibitory concentration: > 1000 nM
Compound 4: only a limit was reported; the forecaster's own chance of this, stated with the estimate: 85%; the middle value does not contradict the limit.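

No step can be read in this assay between compound 4 and either compound 3 or compound 1, as each of these compounds reports only a limit. The compounds shown leave open whether any of these changes alters potency, and by how much, with every reading at the same limit: the limit of > 1000 nM in this assay, at which 4 of the 4 values shown sit.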